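Swapping the ester acyl group for a furan ring

The compounds below may be only part of what the source reports. "The series", "measured", "known", "first", "only" and "open" are said of these compounds alone.

Compound 1, `CCC(C)(O)CC(=O)O[C@H](CC=C(C)C)C1=CC(=O)c2c(O)ccc(O)c2C1=O`, gives 25200 nM in a functional assay on HeLa cells (Homo sapiens) for cytotoxicity, read by MTT assay; a lower number here means a stronger inhibitor, a higher number a weaker inhibitor.
Compound 2, `COC(C)CO[C@H](CC=C(C)C)C1=CC(=O)c2c(O)ccc(O)c2C1=O`, gives 53400 nM in this assay.
Compound 3, `CC[C@](C)(O)CC(=O)O[C@H](CC=C(C)C)C1=CC(=O)c2c(O)ccc(O)c2C1=O`, gives 30200 nM in this assay.

Compound 3 sits second highest of the three numbers. Its nearest neighbour is compound 1, and the step between them, a 1.2-fold higher number from compound 1 to compound 3 (0.08 log units; within the scatter), lies within the scatter, as does its gap to compound 2, a 1.8-fold lower number from compound 2 to compound 3 (0.25 log units; within the scatter). Going by the values given here, the only step that goes beyond the scatter is a 2.1-fold higher number from compound 1 to compound 2 (0.33 log units; beyond the scatter), which replaces the whole ester by an ether.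

Compound 4, `CC(C)=CC[C@@H](OC(=O)c1ccco1)C1=CC(=O)c2c(O)ccc(O)c2C1=O`, has not been measured. It differs from compound 3 in one place: furan-2-yl in place of 2-hydroxy-2-methylbutyl on a carbonyl carbon. Among the compounds with values here, no measured step changes only the acyl group of the ester while keeping the ester itself, so the steps above give only loose guidance. They show that changes at this position moved the numbers by little, so only a small step in either direction is expected in this assay.

Compound 4 is expected to give 30000 nM, within a range from 10000 nM to 90000 nM, which means an expected step of a 1.0-fold lower number from compound 3 to compound 4 (0.00 log units; within the scatter).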

Compound 4, half-maximal inhibitory concentration: 80300 nM
The estimate for compound 4 lay 2.7-fold (0.43 log units) below the measured number, and the stated range covers the measured number.
By their numbers in this assay, from the lowest: compounds 1, 3, 2 and 4 (each within the scatter of the next, the first and the last beyond it).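

Within the ester, the acyl group matters in this assay: furan-2-yl in place of 2-hydroxy-2-methylbutyl gives a step beyond the scatter, both against the chain with its stereocentre defined (a 2.7-fold higher number from compound 3 to compound 4 (0.42 log units; beyond the scatter)) and against the chain drawn without one (a 3.2-fold higher number from compound 1 to compound 4 (0.50 log units; beyond the scatter)). Keeping the ester is therefore not enough to stay close to those two compounds, since the ester compound 4 and the ether compound 2 remain within the scatter of each other (a 1.5-fold higher number from compound 2 to compound 4 (0.18 log units; within the scatter)). The data shown give no measured reason for this step.

The change removes the hydroxyl group and brings in the ring together, so the compounds shown cannot say which of the two counts. Going by these compounds, a plain 2-methylbutyl chain, a phenyl or thiophene ring on the carbonyl carbon, or an amide in place of the ester all remain open.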